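The source may hold more compounds than are shown below. What is called first, only, known or untested is meant among the compounds shown, and "the series" means these compounds.

Measured in an ADME assay on microsomes from liver (Homo sapiens) for metabolic stability, tested at 2.5 uM; a lower number here means slower removal, a higher number faster removal of the compound:
compound 1 `COc1cccc(-c2c(S(=O)(=O)c3cc(Cl)cc(Cl)c3)cnc3c(F)cccc23)c1` — 2.31 mL/min
compound 2 `O=S(=O)(c1cc(Cl)cc(Cl)c1)c1cnc2c(F)cccc2c1-c1ccccc1F` — 0.44 mL/min
compound 3 `Cc1ccc(S(=O)(=O)c2cnc3c(F)cccc3c2-c2ccc(F)cc2)cc1F` — 2.75 mL/min

Compound 2 stands lowest of the three numbers in this assay; compound 1 and compound 3 both sit higher, beyond the scatter. Among the compounds with values here, the one single-point step, a 5.3-fold lower number from compound 1 to compound 2 (0.72 log units; beyond the scatter), concerns the aryl group on the aromatic carbon, not the sulfonyl side. Compound 4 `O=S(=O)(c1cccc(F)c1)c1cnc2c(F)cccc2c1-c1ccccc1F` differs from compound 2 as follows: 3-fluorophenyl in place of 3,5-dichlorophenyl on a sulfonyl sulfur. Within the data shown here, no measured step changes the group on the sulfonyl sulfur, so nothing bears directly on this change; compound 3 carries another sulfonyl aryl but differs from compound 2 in two places, so only its value is known. The expected step of a 2.0-fold higher number from compound 2 to compound 4 (0.31 log units; beyond the scatter) is therefore uncertain, set modestly upward since compound 2 is the low end. Compound 4 is estimated at 0.9 mL/min, range 0.3 mL/min to 2.7 mL/min.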

Compound 4, intrinsic clearance in a liver preparation (reported as CLH), per the amount of preparation that the assay uses: 0.21 mL/min
For compound 4 the middle estimate is 4.3-fold (0.63 log units) above the measured one; measured number below the stated range.
By their numbers in this assay, from the lowest: compound 4; then compound 2; then compounds 1 and 3 (each within the scatter of the next).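

In this assay the group on the sulfonyl sulfur now has a step of its own: 3-fluorophenyl in place of 3,5-dichlorophenyl gives a 2.1-fold lower number from compound 2 to compound 4 (0.32 log units; beyond the scatter) with the rest of the molecule unchanged. With the 2-fluorophenyl group kept, the chlorine atoms are therefore not required for a low number. No available measurement explains this step.

From the compounds shown here alone, whether the step carries over to the 3-methoxyphenyl compound 1 remains open. Also open, going by these compounds, is how a piperidine or a cyclohexyl group would behave on the sulfonyl sulfur.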